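The source may report more compounds than this note shows. Statements on the series, on what has been measured and on what is new or still open speak of the compounds shown alone.

Measured compounds:
- Compound 1, `O=C(CSc1nnc(-c2ccncc2)o1)N/N=C/c1ccccc1`: 16700 nM
- Compound 2, `O=C(CSc1nnc(-c2ccncc2)o1)N/N=C/c1ccc(Br)cc1`: 21300 nM

Both compounds were tested in a functional assay on SW 1116 cells (Homo sapiens) for cytotoxicity, read by MTT assay, with a stated time of 48 h; a lower number here means a stronger inhibitor, a higher number a weaker inhibitor. Compound 2 gives the higher of the two numbers, but the gap to compound 1, a 1.3-fold higher number from compound 1 to compound 2 (0.11 log units; within the scatter), falls within the scatter, so the two compounds cannot be told apart on these data.

Compound 3, `O=C(CSc1nnc(-c2ccncc2)o1)N/N=C/c1ccc(O)cc1`, is the next member of the series and has not yet been measured. The change from compound 2 is hydroxy in place of bromo on an aromatic carbon. Among the compounds with values here, only one measured step exists, and it concerns the same position: a 1.3-fold higher number from compound 1 to compound 2 (0.11 log units; within the scatter), a change of bromo for hydrogen that left the number essentially unchanged. That step speaks to the same place on the ring but not to a hydroxy group, so it bears on the present step only loosely.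

The expected step in this assay is therefore a 1.2-fold lower number from compound 2 to compound 3 (0.07 log units; within the scatter), not beyond the scatter in either direction. Compound 3 is estimated at 18000 nM, with a range from 7000 nM to 45000 nM.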

Compound 3, half-maximal inhibitory concentration: 12200 nM
Compound 3: middle estimate off by 1.5-fold (0.17 log units), on the high side; the measured number falls inside the stated range.
By their numbers in this assay, from the lowest: compounds 3, 1 and 2 (each within the scatter of the next).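

In this assay, putting hydroxy in place of bromo, on an aromatic carbon para to a large group, gives a 1.7-fold lower number from compound 2 to compound 3 (0.24 log units; within the scatter) and, set against hydrogen at the same place, gives a 1.4-fold lower number from compound 1 to compound 3 (0.14 log units; within the scatter) as the second step. The earlier pair covered only hydrogen and bromo; the series now adds a group that counts a hydrogen-bond donor and a hydrogen-bond acceptor where bromo counts neither, and even so compounds 1, 2 and 3 cannot be told apart, so that difference in the counts has no readable consequence at this place in this assay. Nothing measured alongside these numbers bears on the result.

On these data alone, whether an amine, a carboxylic acid or a longer chain such as ethoxy at this same place would carry the number beyond the scatter remains open, since hydrogen, bromo and hydroxy alone do not show whether this position matters at all. Also open, as far as these compounds go, is whether the same indifference holds when the shared core is changed elsewhere, as all three compounds keep it intact.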